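This account rests on a few compounds, and the source may have more. Where it says the series, first, only, none or still open, it means among the compounds named here.

Working notes on the series.

Of the compounds shown here, two carry numbers so far. Compound 1 `CNC(=O)c1cc(C(=O)NC2CCC2)cn(Cc2cccc(NC)c2)c1=O` in a physicochemical assay for lipophilicity, at pH 7.4 (a lower number here means a more polar compound, a higher number a more lipophilic compound), gives 3.6. Compound 2 `CNC(=O)c1cc(C(=O)NC2CC2)cn(CC2CCCOC2)c1=O` in this assay gives 2, the lowest of the two numbers; its nearest neighbour is compound 1, which sits higher by a gap that lies beyond the scatter. The two structures differ in more than one place, so the gap is read as a whole and not assigned to any single change.

Compound 3 `CNC(=O)c1cc(C(=O)NC2CC2)cn(Cc2cccc(F)c2)c1=O` has not yet been measured in this assay. Relative to compound 2 the change is 3-fluorophenyl in place of oxan-3-yl on a saturated chain carbon bound to an aromatic nitrogen. Against the gap between compound 1 and compound 2, a sizeable upward step is expected here rather than none within the scatter. For compound 3 the estimated step from compound 2 is a number 1.50 log units higher from compound 2 to compound 3 (beyond the scatter). Compound 3 is accordingly expected to give about 3.5 in this assay, within a range of 2.9 to 4.1, an expectation resting on compound 1 giving 3.6.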

Compound 3, distribution coefficient: 3.2
Beside the measured number, compound 3's estimate is 0.30 log units above it; measured number inside the range.
By their numbers in this assay, from the lowest: compound 2; then compound 3; then compound 1.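

In this assay, among these compounds, 3-fluorophenyl in place of oxan-3-yl on a saturated chain carbon bound to an aromatic nitrogen gives a number 1.20 log units higher from compound 2 to compound 3 (beyond the scatter), the first step that can be tied to a change in one place. This position alone can therefore carry a large shift in the read-out, with the rest of the structure held constant. Nothing on hand bears on why the step has this size, and the loss of the ring oxygen, the change to an aromatic ring and the entry of fluorine remain a single undivided change.

On these data alone, whether an unsubstituted phenyl or a pyridyl on the same chain carbon would stand nearer compound 2 or compound 3 remains open. Also open, as far as these compounds go, is whether this change keeps its size when the rest of the structure differs.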